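A few compounds are considered here, and "the series" means these few. Any claim that something is new, unique, unknown or untested is made for them only; others in the source may bear on it.

Measured compounds:
- compound 1, `COc1ccc(/C=N/NC(=O)CSc2nnc(-c3ccncc3)o2)cc1`: 20300 nM
- compound 2, `O=C(CSc1nnc(-c2ccncc2)o1)N/N=C/c1cccc(C(F)(F)F)c1`: 14900 nM

Both compounds share the same core, a pyridinyl-substituted ring joined through a sulfur-bearing chain to a hydrazide whose far end carries a substituted phenyl ring. In a functional assay on SW 1116 cells (Homo sapiens) for cytotoxicity, read by MTT assay, with a stated time of 48 h (a higher number here means a weaker inhibitor, a lower number a stronger inhibitor), compound 1 gives 20300 nM, the higher of the two numbers recorded so far. Its only comparator, compound 2, gives 14900 nM; the gap between the two lies within the usual scatter of this kind of measurement, so the two cannot be ranked against each other.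

Compound 3, `O=C(CSc1nnc(-c2ccncc2)o1)N/N=C/c1cc(Br)ccc1O`, has not yet been measured. It differs from compound 1 in one place: 5-bromo-2-hydroxyphenyl in place of 4-methoxyphenyl on a carbon with a double bond to nitrogen. Within the data shown here, no measured pair shows what such a swap does in this assay, so any expectation rests on the structural change alone and on the narrow spread of the two recorded numbers. A step from compound 1 to compound 3 of modest size, toward a lower number, is expected, about a 2.0-fold lower number from compound 1 to compound 3 (0.31 log units; beyond the scatter), but a step of no size beyond the scatter is also plausible. For compound 3 in this assay the estimated value is 10000 nM, within a range from 2500 nM to 40000 nM.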

Compound 3, half-maximal inhibitory concentration: 8150 nM
Estimate against measurement, compound 3: 1.2-fold (0.09 log units) above; low and high end bracket the measured number.
By their numbers in this assay, from the lowest: compounds 3, 2 and 1 (each within the scatter of the next, the first and the last beyond it).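

In this assay, among these compounds, the first step between measured compounds that differ in one place is a 2.5-fold lower number from compound 1 to compound 3 (0.40 log units; beyond the scatter). It shows that changing the group on the carbon with a double bond to nitrogen can move the number beyond the usual scatter, something the two earlier compounds, too close to be ranked, could not show. This swap changes several things at once: 5-bromo-2-hydroxyphenyl brings in a bromine and a hydrogen-bond donor and loses the methoxy group, so the step belongs to the whole swap and not to any one of these, and nothing available explains why the number falls.

From the compounds shown here alone, whether the bromine, the hydroxyl or the loss of the methoxy group accounts for the step stays open, as does whether the two new groups need each other. Also open, going by these compounds, is what a different kind of group would do at this place, such as an amine or a carboxylic acid on the phenyl ring, or a longer chain between that ring and the carbon with a double bond to nitrogen.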